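The source may hold more compounds than are shown below. What is called first, only, known or untested is meant among the compounds shown, and "the series" means these compounds.

Working notes on a small set of N-benzyl amines built on a shared core.

Compound 1 `COc1ccc(CN(Cc2ccc(C(C)(C)C)cc2)Cc2cc3cc(C)ccc3[nH]c2=O)cc1` carries a 4-methoxybenzyl group on the amine nitrogen. In a toxicity assay on MDCK cells (Canis lupus familiaris) for cytotoxicity, read by crystal violet staining, with a stated time of 48 h (on this read-out lower numbers stand for higher toxicity in this test and higher numbers for lower toxicity in this test), compound 1 gives > 10000 nM, which is a limit of the assay and not a number. Compound 2 `Cc1ccc2[nH]c(=O)c(CN(Cc3ccc(N(C)C)cc3)Cc3ccc(C(C)(C)C)cc3)cc2c1` carries a 4-(dimethylamino)benzyl group instead. In this assay compound 2 gives > 5000 nM, also a limit. Compound 3 `Cc1ccc2[nH]c(=O)c(CN(Cc3ccc(C(C)(C)C)cc3)C(C)c3ccc(N(C)C)c(Cl)c3)cc2c1` differs from compound 2 by 1-(3-chloro-4-(dimethylamino)phenyl)ethyl in place of 4-(dimethylamino)benzyl on an amine nitrogen. In this assay, among the measured compounds shown here, compound 3 gives 9800 nM, the only number in the set.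

The change from compound 2 to compound 1 is methoxy in place of dimethylamino on an aromatic carbon; its size is a step that the two limits leave unreadable from compound 2 to compound 1, because the limit of > 10000 nM in this assay, at which 1 of the 3 values shown sits, and the limit of > 5000 nM in this assay, at which 1 of the 3 values shown sits, both hide the step. The step of an at least 1.0-fold lower number from compound 1 to compound 3 (0.00 log units; that floor lies within the scatter) stays within the scatter, and a step that the limit leaves unreadable from compound 2 to compound 3 is again hidden by a limit.

Compound 4 `COc1ccc(C(C)N(Cc2ccc(C(C)(C)C)cc2)Cc2cc3cc(C)ccc3[nH]c2=O)cc1Cl` is not yet measured. It differs from compound 3 by methoxy in place of dimethylamino on an aromatic carbon. This is the same kind of change as that from compound 2 to compound 1, not the same: here the place is ortho to a chloro group, whereas in compound 1 it is only para to a large group. Given that the earlier step is unreadable and that compound 3 sits at 9800 nM, the step to compound 4 is expected to be a 1.0-fold higher number from compound 3 to compound 4 (0.01 log units; within the scatter). For compound 4 the estimate is 10000 nM, with a range from 5000 nM to 20000 nM.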

Compound 4, half-maximal cytotoxic concentration: > 10000 nM
Compound 4: no number, only a limit (the forecaster's own chance of this, stated with the estimate: 50%); the middle value sits exactly at the limit.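

In this assay compound 4 gives > 10000 nM, which is a limit of the assay and not a number. On the branch that carries the chloro group, methoxy in place of dimethylamino reads only as an at least 1.0-fold higher number from compound 3 to compound 4 (0.00 log units; that floor lies within the scatter), so this pair shows no lower number with methoxy but gives no true size for the step. The same change from compound 2 to compound 1 and the other steps to compound 4 cannot be read, so the series does not show whether the change has the same size in both settings, and compound 1 and compound 4 share one limit: the limit of > 10000 nM in this assay, at which 2 of the 4 values shown sit.

The compounds shown leave open how much of the difference between the two branches belongs to the chloro group and how much to the added methyl of the 1-phenylethyl link, since compound 2 and compound 3 differ in both at once. Also open, on these data alone, is whether a hydroxy group or a longer alkoxy chain in place of the methoxy, or a fluoro group in place of the chloro group, would give a number and not a limit in this assay.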